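The compounds below may be only part of what the source reports. "The series", "measured", "known", "first", "only" and "open" are said of these compounds alone.

All three measured compounds share one core and differ only in the group on one aromatic carbon. Compound 1 `Cc1cc(C(=O)O)nn1Cc1cc(Br)ccc1OCc1ccc(Cl)cc1Cl` carries bromo there, and in an assay on CHO-K1 cells for displacement of a labelled ligand from prostaglandin E2 receptor EP1 subtype (Homo sapiens) (a lower number here means a stronger inhibitor, a higher number a weaker inhibitor), compound 1 gives 0.132 nM. Compound 2 `Cc1cc(C(=O)O)nn1Cc1cc(Cl)ccc1OCc1ccc(Cl)cc1Cl` has chloro in place of bromo. In this assay compound 2 gives only a limit, < 2000 nM, and not a number. Compound 3 `Cc1cc(C(=O)O)nn1Cc1ccccc1OCc1ccc(Cl)cc1Cl` has hydrogen at that carbon. In this assay compound 3 likewise gives only a limit, < 2000 nM. Compound 3 therefore stands at a limit, and the second value besides it that is a limit is that of compound 2 (the limit of < 2000 nM in this assay, at which 2 of the 3 values shown sit). The step from compound 1 to compound 2 is a step that the limit leaves unreadable from compound 1 to compound 2, from compound 1 to compound 3 it is a step that the limit leaves unreadable from compound 1 to compound 3, and from compound 2 to compound 3 it is a step that the two limits leave unreadable from compound 2 to compound 3; none of them has a readable size.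

Compound 4 `Cc1cc(C(=O)O)nn1Cc1cc(F)ccc1OCc1ccc(Cl)cc1Cl` introduces the change (fluoro in place of hydrogen on an aromatic carbon). Since no measured step can be read, the direction and size of this step rest on little, and a wide range is expected. The step from compound 3 to compound 4 is expected to be a step that the limit leaves unreadable from compound 3 to compound 4. Compound 4 is estimated at 100 nM, with a range from 1 nM to 2000 nM.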

Compound 4, half-maximal inhibitory concentration: 355 nM
For compound 4 the middle estimate is 3.6-fold (0.55 log units) below the measured one, within the range that was stated.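

Compound 4 gives the series its first readable step at this position. In this assay, fluoro in place of bromo on this aromatic carbon produces a 2700-fold higher number from compound 1 to compound 4 (3.43 log units; beyond the scatter), which shows that the group at this one carbon can by itself move the read-out by a large margin while the rest of the shared core stays unchanged. The steps linking compound 4 with compound 2 and with compound 3 still have no readable size, because those two compounds sit at a limit rather than at a number: the limit of < 2000 nM in this assay, at which 2 of the 4 values shown sit.

The compounds shown therefore leave open where chloro and hydrogen fall relative to fluoro and bromo on this carbon, so no order can be given across all four groups. They also leave open whether the strong binding of compound 1 is particular to bromo, or whether a group such as iodo, methyl, methoxy, trifluoromethyl or nitrile on the same carbon would give a similar number in this assay.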